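Trading methyl for chloro on an aromatic ring

A few compounds are considered here, and "the series" means these few. Any claim that something is new, unique, unknown or untested is made for them only; others in the source may bear on it.

In a functional assay on thoracic aorta (Rattus norvegicus, strain Wistar), with a stated time of 15 min (on this read-out lower numbers stand for an effect already at smaller amounts and higher numbers for an effect only at larger amounts of compound), compound 1 `CCOc1ccc(F)cc1C(C)NC(=O)N(C)S(=O)(=O)c1ccc(Cl)cc1` gives 24500 nM, compound 2 `CCOc1ccc(Cl)cc1C(C)NC(=O)N(C)S(=O)(=O)c1ccc(Cl)cc1` gives 14600 nM and compound 3 `CCOc1ccc(Br)cc1C(C)NC(=O)N(C)S(=O)(=O)c1ccc(C)cc1` gives 28600 nM. Compound 3 lies within the usual scatter of both other compounds, so its value cannot be clearly ranked against theirs.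

Compound 4 `CCOc1ccc(Br)cc1C(C)NC(=O)N(C)S(=O)(=O)c1ccc(Cl)cc1` is compound 3 with one change: chloro in place of methyl on an aromatic carbon. This is chloro in place of methyl on an aromatic carbon, turning 4-methylphenyl into 4-chlorophenyl. Within the data shown here, no measured pair makes this exact swap, so the evidence is indirect. Among the measured compounds shown here, the only measured step, a 1.7-fold lower number from compound 1 to compound 2 (0.22 log units; within the scatter), is a different swap, chloro in place of fluoro, and stays within the scatter. Compound 1 and compound 2 already carry the 4-chlorophenyl group, and compound 1 at 24500 nM and compound 2 at 14600 nM suggest a slightly lower number at most. No change beyond the scatter is therefore expected in this assay. The expected step is a 1.6-fold lower number from compound 3 to compound 4 (0.20 log units; within the scatter). For compound 4 the estimated value is 18000 nM, with an expected range from 9000 nM to 36000 nM.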

Compound 4, half-maximal effective concentration: 55700 nM
The estimate for compound 4 lay 3.1-fold (0.49 log units) below the measured number; measured number outside the range, above it.
By their numbers in this assay, from the lowest: compounds 2, 1, 3 and 4 (each within the scatter of the next, the first and the last beyond it).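

In this assay the swap from 4-methylphenyl to 4-chlorophenyl shows a 1.9-fold higher number from compound 3 to compound 4 (0.29 log units; within the scatter) and so, with a direct pair now in hand, this change on this ring does not move the read-out clearly. The clearer differences lie on the other aromatic ring: with 4-chlorophenyl held fixed, bromo in place of chloro shows a 3.8-fold higher number from compound 2 to compound 4 (0.58 log units; beyond the scatter) while bromo in place of fluoro shows a 2.3-fold higher number from compound 1 to compound 4 (0.36 log units; beyond the scatter) and both steps are modest. No measurement available here accounts for these differences.

Methyl and chloro are the only groups shown at this ring position, so a methoxy group, a trifluoromethyl group or an amine there remains an open case. Going by these compounds, whether the methyl-to-chloro swap would also stay within the scatter with fluoro or chloro on the other ring also remains open.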